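Swapping one side group on a well-tolerated compound

The compounds below may be only part of what the source reports. "The series", "measured", "known", "first", "only" and "open" are said of these compounds alone.

Measured in an ADME assay on cells (Homo sapiens) for cytotoxicity, read by resazurin assay, with a stated time of 5 days; a higher number here means that more compound is tolerated, a lower number that less compound is tolerated:
Compound 1 `COc1ccc(-c2nc(CNc3cccc(Cl)c3)nc3ccsc23)cn1`: > 50000 nM
Compound 2 `O=c1ccc(-c2nc(CS(=O)(=O)c3cccc(Cl)c3)nc3ccsc23)c[nH]1`: > 50000 nM

Compound 1 gives no exact number, only a limit, and the same holds for compound 2: the limit of > 50000 nM in this assay, at which 2 of the 2 values shown sit. Compound 3 `COc1ccc(-c2nc(CSc3cc(Cl)ccc3Cl)nc3ccsc23)cn1` differs from compound 1 in one place, on a saturated chain carbon bound to an aromatic carbon: (2,5-dichlorophenyl)sulfanyl in place of (3-chlorophenyl)amino on a saturated chain carbon bound to an aromatic carbon. For the measured compounds named here, no measured pair shows what such a swap does in this assay, so only a small shift towards less compound tolerated is expected. The expected change is an at least 1.2-fold lower number from compound 1 to compound 3 (0.09 log units; that floor lies within the scatter). A result that is again only a limit would fit this expectation. For compound 3 the estimated value is 40000 nM, with an expected range from 15000 nM to 50000 nM.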

Compound 3, half-maximal cytotoxic concentration: > 50000 nM
Compound 3 gave a limit, no number; the forecaster's own chance of this, stated with the estimate: 60%; middle value at least 1.2-fold (0.09 log units) from the limit.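

For the compounds shown here, compound 1 and compound 3 each give only a limit, not a number, in this assay, so no step between them can be read: the limit of > 50000 nM in this assay, at which 3 of the 3 values shown sit.

As far as these compounds go, what this swap of side groups does to cell tolerance remains open, as does the concentration at which any of the three compounds would harm cells.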